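Fluoro to Chloro at the Edge of Measurable Inhibition

A few compounds are considered here, and "the series" means these few. Any claim that something is new, unique, unknown or untested is made for them only; others in the source may bear on it.

Compound 1 `COc1ccc(C(=O)/C(=C/C2CCCCC2)COC(C)=O)cc1` gives 24000 nM in a functional assay on MCF7 cells (Homo sapiens) for inhibition, read by XTT assay, with a stated time of 48 h; a higher number here means a weaker inhibitor, a lower number a stronger inhibitor.
Compound 2 `CCC(/C=C(\COC(=O)c1ccccc1)C(=O)c1ccc(OC)cc1)CC` gives 28000 nM in this assay.
Compound 3 `COc1ccc(C(=O)/C(=C/c2ccccc2F)CCOC(C)=O)cc1` reaches only the limit > 100000 nM in this assay.

Among the three measured compounds, compound 3 is the one for which no number was obtained: its result is a limit, and it sits at the limit of > 100000 nM in this assay, at which 1 of the 3 values shown sits. Within the data shown here, compounds 1 and 2 show numbers, but no step between any two of the measured compounds is given, so only their values can be compared side by side.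

The unmeasured compound 4 `COc1ccc(C(=O)/C(=C/c2ccccc2Cl)CCOC(C)=O)cc1` differs from compound 3 in a single place: chloro in place of fluoro on an aromatic carbon. One halogen replaces another of the same kind of position, and nothing else in the structure moves.

With compound 3 standing at a limit, there is no measured anchor for a direction, and no step beyond the usual scatter is expected from compound 3 to compound 4 in this assay. Compound 4 is therefore expected to give about 100000 nM, within 30000 nM to 300000 nM, with the step of a number no higher from compound 3 to compound 4 (the limit leaves the size open) estimated as close to nothing.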

Compound 4, half-maximal inhibitory concentration: > 100000 nM
Compound 4: only a limit was reported; the forecaster's own chance of this, stated with the estimate: 65%; the middle value sits exactly at the limit.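

Compound 3 and compound 4 each give only a limit rather than a number, so no step can be read between them: the limit of > 100000 nM in this assay, at which 2 of the 4 values shown sit.

The compounds shown leave open whether chloro in place of fluoro makes any real difference in this assay.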